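This account rests on a few compounds, and the source may have more. Where it says the series, first, only, none or still open, it means among the compounds named here.

In a functional assay on NCI-H522 cells (Homo sapiens) for cytotoxicity, with a stated time of 3 days (on this read-out higher numbers stand for weaker inhibition and lower numbers for stronger inhibition), compound 1 (`C#Cc1nc(C(=O)N2CCN(c3ccc(Cl)cc3)CC2)cs1`) gives 28 nM and holds the lower of the two actual numbers shown. Compound 3 (`Ic1nc2ccccc2o1`) lies nearest at 11700 nM and stands far beyond the scatter from compound 1. Compound 2 (`N#Cc1nccs1`) is recorded only as a limit (> 40000 nM). Compound 4 (`C#Cc1nc(C(=O)N2CCN(c3ccc(F)cc3)CC2)cs1`) keeps the core of compound 1 and differs at one place (fluoro in place of chloro on an aromatic carbon): fluoro in place of chloro on an aromatic carbon, para to a large group. Going by the values given here, no measured pair shows this change, so the expectation rests on the swap alone. A small step toward weaker inhibition is expected in this assay (a 2.1-fold higher number from compound 1 to compound 4 (0.33 log units; beyond the scatter)), possibly not beyond the scatter. In this assay compound 4 is estimated at 60 nM with an expected range from 20 nM to 200 nM pending measurement.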

Compound 4, half-maximal inhibitory concentration: 64 nM
Compound 4: the middle estimate sits 1.1-fold (0.03 log units) below what was measured; measured number inside the range.
By their numbers in this assay, from the lowest: compound 1; then compound 4; then compound 3. At a limit, above all of these: compound 2.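

In this assay, the exchange of 4-chlorophenyl for 4-fluorophenyl gives a 2.3-fold higher number from compound 1 to compound 4 (0.36 log units; beyond the scatter). Going by these compounds alone, this is the first measured step at this place, on an aromatic carbon para to a large group, and it shows that the read-out responds to the choice of halogen there, though only modestly. Nothing in the data shown bears on the reason for this step. As far as these compounds go, what a methoxy group, an amine or a carboxylic acid at this place would do stays open. So does whether the step holds on other cell lines.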